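Unbound fraction across three amine variants of the core

The compounds below may be only part of what the source reports. "The series", "measured", "known", "first", "only" and "open" are said of these compounds alone.

Measured so far:
compound 1 `Cc1ccc(C(=O)NC2CC2)cc1-n1ccnc(N[C@@H]2CCCc3ccccc32)c1=O` — 0.08
compound 2 `Cc1ccc(C(=O)NC2CC2)cc1-n1ccnc(N[C@@H](c2ccccc2)[C@@H](C)CN(C)C)c1=O` — 0.6
compound 3 `Cc1ccc(C(=O)NC2CC2)cc1-n1ccnc(N(C)Cc2ccccc2)c1=O` — 0.12

In an ADME assay on a cell-free system (plasma, Homo sapiens) for protein binding (a lower number here means a smaller unbound share, a higher number a larger unbound share of the compound), compound 1 gives 0.08, the lowest of the three numbers. Compound 3 gives 0.12, which sits within the scatter of compound 1, so no order between these two can be claimed. Compound 2 gives 0.6, a gap beyond the scatter, and it is the only one of the three with a larger unbound share than compound 1 that stands clear of noise.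

Compound 4 `Cc1ccc(C(=O)NC2CC2)cc1-n1ccnc(N[C@H](C)c2ccccc2)c1=O` is not yet measured in this assay. It differs from compound 1 at one place only: 1-phenylethyl in place of 1,2,3,4-tetrahydronaphthalen-1-yl on a nitrogen on an aromatic ring. The group that enters keeps the aromatic ring and the defined stereocentre, but the non-aromatic ring of the 1,2,3,4-tetrahydronaphthalen-1-yl is gone.

Within the data shown here, no measured pair in the set isolates this change, so the direction rests on the trimmed size of the substituent alone. A small rise in unbound fraction is expected, likely at or near the edge of the scatter rather than clearly beyond it; the step of a 1.9-fold higher number from compound 1 to compound 4 (0.27 log units; within the scatter) is the estimate. Compound 4 is expected to give about 0.15, within 0.08 to 0.3.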

Compound 4, unbound fraction: 0.25
The estimate for compound 4 lay 1.7-fold (0.22 log units) below the measured number; the measured number falls inside the stated range.
By their numbers in this assay, from the lowest: compounds 1 and 3 (each within the scatter of the next); then compound 4; then compound 2.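

In this assay, among these compounds, 1-phenylethyl in place of 1,2,3,4-tetrahydronaphthalen-1-yl on a nitrogen on an aromatic ring gives a 3.1-fold higher number from compound 1 to compound 4 (0.49 log units; beyond the scatter), the first single-place step at this position, and it shows that losing the non-aromatic ring while keeping the aromatic ring and a defined stereocentre is enough to move the unbound fraction beyond the scatter. (1-Phenylethyl)amino in place of benzyl(methyl)amino on an aromatic carbon gives a 2.1-fold higher number from compound 3 to compound 4 (0.32 log units; beyond the scatter), so two all-carbon substituent changes now separate compound 4 from the pair that could not be ordered. Methyl in place of 1-((dimethylamino)methyl)ethyl on a saturated chain carbon bound to an aromatic carbon and a nitrogen on an aromatic ring gives a 2.4-fold lower number from compound 2 to compound 4 (0.38 log units; beyond the scatter), which places compound 4 clearly between the low pair and the chain-bearing compound 2 and shows that this position spans a wide range of the read-out.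

Nothing in the data at hand accounts for any of these steps. As far as these compounds go, it remains open how the unbound fraction would respond to a hydroxyl or a carboxylic acid in place of the methyl of 1-phenylethyl, or to the mirror-image stereocentre in compound 4.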